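Chloro substitution on a four-acyl tetronic-acid series in Huh-7

A few compounds are considered here, and "the series" means these few. Any claim that something is new, unique, unknown or untested is made for them only; others in the source may bear on it.

Measured compounds:
- compound 1, `O=C(O)/C(O)=C/C(=O)c1ccc(OCc2ccccc2)cc1`; in an ADME assay on Huh-7 cells (Homo sapiens) for cytotoxicity (a lower number here means that less compound is tolerated, a higher number that more compound is tolerated), compound 1 gives > 100000 nM, a limit of the assay.
- compound 2, `O=C(O)/C(O)=C/C(=O)c1ccc(OCc2ccc(Cl)cc2)cc1`; in this assay compound 2 gives > 100000 nM, a limit of the assay.
- compound 3, `O=C(O)/C(O)=C/C(=O)c1cccc(NCc2ccccc2)c1`; in this assay compound 3 gives > 100000 nM, a limit of the assay.

Compound 1 and compound 2 share one core and differ by chloro in place of hydrogen on an aromatic carbon. Since both sit at the limit, the step that the two limits leave unreadable from compound 1 to compound 2 cannot be read. Compound 3 carries a different core; the difference between the two cores is not broken down here.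

Compound 4 is `O=C(O)/C(O)=C/C(=O)c1cccc(NCc2ccc(Cl)cc2)c1`, not yet measured in this assay. It stands to compound 3 as compound 2 stands to compound 1: the change is chloro in place of hydrogen on an aromatic carbon, the same change as between compound 1 and compound 2, occurring twice among the compounds shown.

For the measured compounds named here, the only guide is the limit of > 100000 nM in this assay, at which 3 of the 3 values shown sit. Going by the values given here, the one measured instance of this change left the value at the limit on the other core, and compound 3 itself sits at the limit, so the same change on the core of compound 3 is expected to leave compound 4 at the limit too. The expected step is a step that the limit leaves unreadable from compound 3 to compound 4, meaning no readable change. For compound 4 the estimate is 150000 nM, with the measurement most likely to be reported again as a limit only.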

Compound 4, half-maximal cytotoxic concentration: > 100000 nM
Compound 4: no number, only a limit; the forecaster's own chance of this, stated with the estimate: 85%; the middle value lies beyond the limit too.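

Compound 3 and compound 4 both sit at a limit in this assay, so the chloro in place of hydrogen on an aromatic carbon gives no readable step, and no new step comes from this pair: the limit of > 100000 nM in this assay, at which 4 of the 4 values shown sit.

None of the compounds shown gives a number in this assay, which leaves open whether phenyl to 4-chlorophenyl shifts the value on either core at all.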